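Anilino substitution pattern against antiproliferative activity

The source may report more compounds than this note shows. Statements on the series, on what has been measured and on what is new or still open speak of the compounds shown alone.

For the measured compounds named here, compound 1 `COc1cc2ncnc(Nc3cccc(Br)c3)c2cc1OCCCN1CCNCCNCCNCC1` stands lowest of the two numbers known in a functional assay on A549 cells (Homo sapiens) for antiproliferative activity, read by MTT assay, with a stated time of 72 h; a lower number here means a stronger inhibitor, a higher number a weaker inhibitor; there compound 1 gives 14700 nM. Compound 2 `COc1cc2ncnc(Nc3cccc(Cl)c3)c2cc1OCCCN1CCNCCNCCNCC1` gives 27100 nM, and the step of a 1.8-fold higher number from compound 1 to compound 2 (0.27 log units; within the scatter) stays within the scatter. Compound 3 `COc1cc2ncnc(Nc3ccc(C#N)cc3F)c2cc1OCCCN1CCNCCNCCNCC1` returns only a limit, > 50000 nM, as recorded by the limit of > 50000 nM in this assay, at which 1 of the 3 values shown sits. The step of an at least 3.4-fold higher number from compound 1 to compound 3 (0.53 log units; beyond the scatter) shows that reworking the aniline weakens the series at least modestly. Compound 4 `CCc1cc(Br)ccc1Nc1ncnc2cc(OC)c(OCCCN3CCNCCNCCNCC3)cc12` differs from compound 1 by 4-bromo-2-ethylphenyl in place of 3-bromophenyl on a nitrogen on an aromatic ring. The bromine is kept, but the ring is substituted differently and gains an ethyl group, so the aniline is reworked as it was in the step of an at least 3.4-fold higher number from compound 1 to compound 3 (0.53 log units; beyond the scatter). A weakening is therefore expected, estimated as a 2.4-fold higher number from compound 1 to compound 4 (0.38 log units; beyond the scatter). Compound 4 is expected to give about 35000 nM, within 12000 nM to 100000 nM.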

Compound 4, half-maximal inhibitory concentration: > 50000 nM
Compound 4: only a limit was reported; the forecaster's own chance of this, stated with the estimate: 30%; at least 1.4-fold (0.15 log units) between middle value and limit.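

In this assay compound 4 returns only a limit, > 50000 nM, so keeping a bromine on the aniline ring does not by itself hold the level of compound 1. The change to 4-bromo-2-ethylphenyl reads an at least 3.4-fold higher number from compound 1 to compound 4 (0.53 log units; beyond the scatter), while the comparison with the chloro compound reads an at least 1.8-fold higher number from compound 2 to compound 4 (0.26 log units; that floor lies within the scatter). The step between compound 3 and compound 4 cannot be read, as both rest on the same limit: the limit of > 50000 nM in this assay, at which 2 of the 4 values shown sit.

The bromine's new place and the added ethyl group change together, and the compounds shown do not separate them. Also open, as far as these compounds go, is whether a methyl or an amine in place of the bromo of 3-bromophenyl would hold the level of compound 1.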